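The source may hold more compounds than are shown below. What is called first, only, known or untested is meant among the compounds shown, and "the series" means these compounds.

All the compounds here share one core and differ only in the phenyl group attached to it. In an ADME assay on microsomes from liver (Rattus norvegicus) for metabolic stability, read by LC-MS, using NADPH, at 37 degrees C (on this read-out higher numbers stand for a longer-lived compound and lower numbers for a shorter-lived compound), compound 1 `Cc1oc(-c2c(F)cccc2F)nc1CN1CCC(C(=O)NCCCN2C[C@H](C)C[C@H](C)C2)CC1`, with fluorines on that phenyl, gives 0.35 h. Compound 2 `Cc1oc(-c2c(Br)cccc2Br)nc1CN1CCC(C(=O)NCCCN2C[C@H](C)C[C@H](C)C2)CC1`, with bromines instead, gives 0.035 h. That swap alone produces a 10-fold lower number from compound 1 to compound 2 (1.00 log units; beyond the scatter).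

Compound 3 `Cc1cccc(-c2nc(CN3CCC(C(=O)NCCCN4C[C@H](C)C[C@H](C)C4)CC3)c(C)o2)c1` gives > 0.5 h, which is a limit of the assay and not a number. The comparisons with it are therefore open-ended: one is an at least 14-fold higher number from compound 2 to compound 3 (1.15 log units; beyond the scatter), and the other is an at least 1.4-fold higher number from compound 1 to compound 3 (0.15 log units; that floor lies within the scatter). Compound 3 thus stands clear of compound 2 but cannot be separated from compound 1.

The next compound, compound 4 `COc1cccc(Cl)c1-c1nc(CN2CCC(C(=O)NCCCN3C[C@H](C)C[C@H](C)C3)CC2)c(C)o1`, changes the same group: 2-chloro-6-methoxyphenyl in place of 3-methylphenyl on an aromatic carbon. It has 2-chloro-6-methoxyphenyl in place of 3-methylphenyl on an aromatic carbon. Among the measured compounds shown here, no measured step makes this exact change, so the nearest guides are the halogen-bearing compounds. Compound 4 also carries a halogen on its phenyl, as do compound 1 at 0.35 h and compound 2 at 0.035 h. A value within the span of those two is expected, which points to a lower number, beyond the scatter. The expected change is an at least 4.1-fold lower number from compound 3 to compound 4 (0.61 log units; beyond the scatter). For compound 4 the estimated half-life is 0.12 h, with an expected range from 0.04 h to 0.4 h.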

Compound 4, half-life: 0.055 h
The estimate for compound 4 lay 2.2-fold (0.34 log units) above the measured number, within the range that was stated.
By their numbers in this assay, from the lowest: compounds 2 and 4 (each within the scatter of the next); then compound 1. At a limit, above all of these: compound 3.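

In this assay, putting 2-chloro-6-methoxyphenyl in place of 3-methylphenyl gives an at least 9.0-fold lower number from compound 3 to compound 4 (0.95 log units; beyond the scatter), so the change at this position shows a clear loss of half-life for a group other than 2,6-dibromophenyl. Compound 3 gives a limit and not a number, so this step is only a floor: the limit of > 0.5 h in this assay, at which 1 of the 4 values shown sits. The halogen-bearing groups do not all behave alike, since set against 2,6-difluorophenyl the new group gives a 6.4-fold lower number from compound 1 to compound 4 (0.80 log units; beyond the scatter), while set against 2,6-dibromophenyl it gives a 1.6-fold higher number from compound 2 to compound 4 (0.20 log units; within the scatter), which leaves those two compounds inseparable even though compound 1, compound 2 and compound 4 all carry halogen on the phenyl.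

The compounds shown cannot say whether the chlorine or the methoxy of 2-chloro-6-methoxyphenyl matters more, as neither stands alone on this phenyl in any compound here. Also open, as far as these compounds go, are how far the half-life of compound 3 reaches beyond its limit, and how a phenyl bearing an amine or a carboxylic acid would fare in this assay.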